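The source may hold more compounds than are shown below. What is called first, only, known or untested is meant among the compounds shown, and "the series" means these compounds.

Of the compounds shown here, two sharing one core have been measured so far in an ADME assay on CCRF-HSB-2 cells (Homo sapiens) for cytotoxicity, with a stated time of 7 days; a higher number here means that more compound is tolerated, a lower number that less compound is tolerated. Compound 1 `CN(C)c1nc(N)nc2c1ncn2/C=C1/CC1(CO)CO` gives > 20000 nM, which is a limit of the assay and not a number. Compound 2 `CCCCCOc1nc(N)nc2c1ncn2/C=C1/CC1(CO)CO` gives > 20000 nM, again a limit. Compound 2 therefore stands at the limit of > 20000 nM in this assay, at which 2 of the 2 values shown sit, and no number places it more exactly.

Compound 3 `Nc1nc(SC2CCCC2)c2ncn(/C=C3/CC3(CO)CO)c2n1` has cyclopentylsulfanyl in place of pentyloxy on an aromatic carbon, next to the ring nitrogen (cyclopentylsulfanyl in place of pentyloxy on an aromatic carbon). The entering group brings a five-membered non-aromatic ring of carbon only.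

For the measured compounds named here, only one measured step bears on this change: a step that the two limits leave unreadable from compound 1 to compound 2, with pentyloxy in place of dimethylamino at the same aromatic carbon. That step has no readable size, so it offers no measure for the new exchange, though it shows two different groups there ending at the same limit. Compound 3 is therefore expected to stay close to compound 2 in this assay, with no firm direction. The expected step is a number no higher from compound 2 to compound 3 (the limit leaves the size open). For compound 3 the estimated half-maximal cytotoxic concentration is 20000 nM, with an expected range from 9000 nM to 40000 nM.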

Compound 3, half-maximal cytotoxic concentration: 91000 nM
Compound 3: the middle estimate sits 4.6-fold (0.66 log units) below what was measured, and the stated range ends below it.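

Neither the step from compound 2 to compound 3 nor the step from compound 1 to compound 3 can be read in this assay, as each begins at a limit of the assay: the limit of > 20000 nM in this assay, at which 2 of the 3 values shown sit.

The compounds shown leave open whether cyclopentylsulfanyl in place of pentyloxy or dimethylamino on this aromatic carbon changes the tolerated concentration at all.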